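This account rests on a few compounds, and the source may have more. Where it says the series, first, only, none or still open, it means among the compounds named here.

Values in a functional assay (aorta) for inhibition, with Oryctolagus cuniculus as the target; on this read-out lower numbers stand for stronger inhibition and higher numbers for weaker inhibition:
- compound 1 `CC1=NC(=S)N(C(=O)OC2CCN(Cc3ccccc3)CC2)C(c2ccccc2C(F)(F)F)/C1=C(\O)OC(C)C`: 5 nM
- compound 2 `CC1=NC(=S)N(C(=O)OC2CCN(Cc3ccccc3)CC2)C(c2ccccc2[N+](=O)[O-])/C1=C(\O)OC(C)C`: 2 nM
- compound 3 `CC1=NC(=S)N(C(=O)OC2CCN(Cc3ccccc3)CC2)C(c2cccc([N+](=O)[O-])c2)/C1=C(\O)OC(C)C`: 4 nM

On these numbers, compound 3 cannot be told apart from either of the other two. The steps that place it are a 1.3-fold lower number from compound 1 to compound 3 (0.10 log units; within the scatter) and a 2.0-fold higher number from compound 2 to compound 3 (0.30 log units; within the scatter). Compound 4 `CC1=NC(=S)N(C(=O)OC2CCN(Cc3ccccc3)CC2)C(c2ccccc2Cl)/C1=C(\O)OC(C)C` differs from it at one place: 2-chlorophenyl in place of 3-nitrophenyl on a saturated ring carbon. Within the data shown here, no measured compound carries chlorine, so the nearest guide is the set of steps between aryl groups. Only one of these lies beyond the scatter, and it is modest: a 2.5-fold lower number from compound 1 to compound 2 (0.40 log units; beyond the scatter). A step no larger than the scatter is therefore expected in this assay, with no firm direction. That expectation corresponds to an estimated 1.3-fold lower number from compound 3 to compound 4 (0.12 log units; within the scatter). For compound 4 the estimated value is 3 nM, with an expected range from 1.2 nM to 8 nM.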

Compound 4, half-maximal inhibitory concentration: 5 nM
Beside the measured number, compound 4's estimate is 1.7-fold (0.22 log units) below it; low and high end bracket the measured number.
By their numbers in this assay, from the lowest: compounds 2, 3, 1 and 4 (each within the scatter of the next, the first and the last beyond it).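

In this assay, the change to 2-chlorophenyl on this saturated ring carbon stays within the scatter in two steps: a 1.3-fold higher number from compound 3 to compound 4 (0.10 log units; within the scatter) and no change at the digits printed from compound 1 to compound 4 (within the scatter). Only a 2.5-fold higher number from compound 2 to compound 4 (0.40 log units; beyond the scatter) lies beyond it, so on this phenyl ring chloro, like trifluoromethyl, stands modestly apart from the nitro of compound 2. The 3-nitrophenyl of compound 3 goes against any simple reading of nitro, since it cannot be told apart from compound 2, compound 1 or compound 4. Going by these compounds, how a methoxy group, an amine or a pyridine ring would read at this position stays open. Nothing at hand explains these steps.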